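Fluorophenyl for Chlorophenyl on a Fused Bicyclic Oxime Ether

The compounds below may be only part of what the source reports. "The series", "measured", "known", "first", "only" and "open" are said of these compounds alone.

Measured in an assay on HepG2 cells for agonist activity at nuclear receptor subfamily 1 group I member 3 (Homo sapiens), read by a luciferase reporter, with a stated time of 23 h; on this read-out higher numbers stand for an effect only at larger amounts of compound and lower numbers for an effect already at smaller amounts:
Compound 1 `Clc1ccc(CO/N=C/c2c(-c3ccc(C4CCCCC4)cc3)nc3sccn23)cc1Cl` gives > 100000 nM, which is a limit of the assay and not a number.
Compound 2 `CCc1nc2sccn2c1/C=N/OCc1ccc(Cl)c(Cl)c1` gives 2600 nM.
Compound 3 `Clc1cccc(-c2nc3sccn3c2/C=N/OCc2ccc(Cl)c(Cl)c2)c1` gives 1100 nM.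

Of the two numbers shown, compound 3 has the lower one, while compound 1 sits at the limit of > 100000 nM in this assay, at which 1 of the 3 values shown sits. Among the compounds with values here, the only measured step, a 2.4-fold lower number from compound 2 to compound 3 (0.37 log units; beyond the scatter), replaces an alkyl group with an aryl group and so does not speak directly to an aryl-for-aryl exchange. Compound 4 `Fc1ccc(-c2nc3sccn3c2/C=N/OCc2ccc(Cl)c(Cl)c2)cc1` carries 4-fluorophenyl in place of 3-chlorophenyl on an aromatic carbon. Within the data shown here, with no measured step bearing on this exchange, no step beyond the scatter is expected. Compound 4 is therefore estimated at 1500 nM, between 500 nM and 5000 nM. This expectation amounts to a 1.4-fold higher number from compound 3 to compound 4 (0.13 log units; within the scatter).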

Compound 4, half-maximal effective concentration: 670 nM
For compound 4 the middle estimate is 2.2-fold (0.35 log units) above the measured one; the measured number falls inside the stated range.
By their numbers in this assay, from the lowest: compounds 4 and 3 (each within the scatter of the next); then compound 2. At a limit, above all of these: compound 1.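

The exchange of 3-chlorophenyl for 4-fluorophenyl in this assay gives a 1.6-fold lower number from compound 3 to compound 4 (0.22 log units; within the scatter), so these two aryl groups are not told apart at this position. Against ethyl, 4-fluorophenyl gives a 3.9-fold lower number from compound 2 to compound 4 (0.59 log units; beyond the scatter), which shows the aryl gain with a second aryl group. Fluoro in place of cyclohexyl gives an at least 140-fold lower number from compound 1 to compound 4 (2.17 log units; beyond the scatter), but compound 1 stands at a limit of the assay and not at a number: the limit of > 100000 nM in this assay, at which 1 of the 4 values shown sits.

Compound 3 and compound 4 change both the halogen and its ring place at once, so neither change can be read alone. Going by these compounds, how an unsubstituted phenyl or an aminophenyl would read here stays open.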